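A few compounds are considered here, and "the series" means these few. Any claim that something is new, unique, unknown or untested is made for them only; others in the source may bear on it.

In an ADME assay on cells (Homo sapiens) for cytotoxicity (a lower number here means that less compound is tolerated, a higher number that more compound is tolerated), compound 1, `Oc1ccc(C#C/C=C/COc2ccc(O)cc2)cc1`, gives < 18000 nM, which is a limit of the assay and not a number. Compound 1 therefore stands only at the limit of < 18000 nM in this assay, at which 1 of the 2 values shown sits. Compound 2, `C=CC(/C=C\c1ccc(O)cc1)c1ccc(O)c(OC)c1`, gives in this assay a value of 24100 nM. Compound 3, `COc1cc(C#C/C=C/COc2ccc(O)cc2)ccc1O`, has not yet been measured in this assay and differs from compound 1 by methoxy in place of hydrogen on an aromatic carbon. Among the measured compounds shown here, no measured step of this kind exists, so the change expected in this assay is a step that the limit leaves unreadable from compound 1 to compound 3, with no direction beyond the usual scatter. Compound 3 is estimated at 16000 nM in this assay, in a range from 6000 nM to 40000 nM.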

Compound 3, half-maximal cytotoxic concentration: < 17000 nM
Compound 3 was reported as a limit; the forecaster's own chance of this, stated with the estimate: 40%; the middle value is on the limit's open side.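

Among the compounds shown here, compound 1 and compound 3 are both reported as limits in this assay, so no step between them can be read. The compounds shown leave open whether methoxy in place of hydrogen on an aromatic carbon changes the value in this assay at all.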